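A Silicon Group in Place of Butyl on the Triple Bond

The source may report more compounds than this note shows. Statements on the series, on what has been measured and on what is new or still open speak of the compounds shown alone.

Among the measured compounds shown here, compound 1 `CCCCC#Cc1c[nH]c(=O)[nH]c1=O` was examined in an ADME assay on A549 cells (Homo sapiens) for cytotoxicity, read by MTT assay (a higher number here means that more compound is tolerated, a lower number that less compound is tolerated), where compound 1 gives 250000 nM, the highest of the two numbers known so far. Compound 2 `CCCCCCC#Cc1cn([C@@H]2O[C@H](CO)[C@@H](O)[C@H]2O)c(=O)[nH]c1=O` gives 87200 nM in this assay, a lower number that lies beyond the scatter. Compound 3 `C[Si](C)(C)C#Cc1c[nH]c(=O)[nH]c1=O` differs from compound 1 in one place: a group of 4 heavy atoms (3 carbon, 1 silicon; no ring) in place of a group of 4 heavy atoms (4 carbon; no ring), on a triple-bonded carbon, a group of 4 heavy atoms (3 carbon, 1 silicon) in place of butyl on a triple-bonded carbon. For the measured compounds named here, no measured pair shows such a change, so the expected step, a 1.3-fold lower number from compound 1 to compound 3 (0.10 log units; within the scatter), is small, none beyond the scatter in either direction. Compound 3 is estimated at 200000 nM, within a range from 60000 nM to 500000 nM.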

Compound 3, half-maximal cytotoxic concentration: 268000 nM
Beside the measured number, compound 3's estimate is 1.3-fold (0.13 log units) below it; the measured number falls inside the stated range.
By their numbers in this assay, from the lowest: compound 2; then compounds 1 and 3 (each within the scatter of the next).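

In this assay, the silicon group in place of butyl on a triple-bonded carbon gives a 1.1-fold higher number from compound 1 to compound 3 (0.03 log units; within the scatter), so this pair does not separate the two groups. Among the compounds shown here, it is the first pair to isolate a change at this place, as compound 2 differs from compound 1 in more than one place. No measurement at hand accounts for this result. Going by these compounds, whether a hydroxymethyl group, an amine or a phenyl group on the triple-bonded carbon would move the number remains open, as does the effect of the silicon group on the core of compound 2.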